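Replacing a Chlorophenyl with a Methoxyphenyl on a Limit Baseline

A few compounds are considered here, and "the series" means these few. Any claim that something is new, unique, unknown or untested is made for them only; others in the source may bear on it.

The series shares one core, seen in compound 1 `COc1cccc(/C=C/C(=O)c2sc(Nc3cccc(C)c3)nc2C)c1`, compound 2 `COc1cccc(/C=C/C(=O)c2sc(Nc3ccc(Cl)cc3)nc2C)c1` and compound 3 `Cc1ccccc1Nc1nc(C)c(C(=O)/C=C/c2ccc(Cl)cc2)s1`, which differ only in their aryl groups. In a functional assay on NCI-H460 cells (Homo sapiens) for cytotoxicity, read by MTT assay (on this read-out higher numbers stand for weaker inhibition and lower numbers for stronger inhibition), compound 1 gives > 25000 nM, a limit of the assay rather than a number. Compound 2 likewise gives > 25000 nM, again a limit. Compound 3, the starting point here, gives > 25000 nM, also a limit, so it stands where every measured compound stands: at the limit of > 25000 nM in this assay, at which 3 of the 3 values shown sit. For the measured compounds named here, the one step among measured compounds, a step that the two limits leave unreadable from compound 1 to compound 2, cannot be sized because both ends are limits.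

Compound 4 `COc1cccc(/C=C/C(=O)c2sc(Nc3ccccc3C)nc2C)c1` is the unmeasured compound. It differs from compound 3 by 3-methoxyphenyl in place of 4-chlorophenyl on a double-bonded chain carbon bound to a double-bonded chain carbon. Going by the values given here, no measured step bears on this change: the aryl group on the chain has not been varied between two numerical values anywhere in the set, and the only measured step is unreadable. Nothing in the data therefore points toward a readable gain, and compound 4 is expected to remain at the same limit, with a step that the limit leaves unreadable from compound 3 to compound 4 that is no change beyond the scatter. Compound 4 is accordingly estimated at 35000 nM, between 15000 nM and 90000 nM.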

Compound 4, half-maximal inhibitory concentration: > 25000 nM
Compound 4 gave a limit, no number; the forecaster's own chance of this, stated with the estimate: 85%; the middle value is on the limit's open side.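

In this assay compound 4 gives > 25000 nM, which is a limit and not a number. None of the steps linking compound 4 to compound 1, compound 2 or compound 3 can be read, as all four compounds stand at the same limit: the limit of > 25000 nM in this assay, at which 4 of the 4 values shown sit.

The compounds shown leave open whether any aryl group on the shared core gives a numerical value in this assay.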